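The source may hold more compounds than are shown below. What is called first, only, known or untested is meant among the compounds shown, and "the series" means these compounds.

Working notes on a short series sharing the core of compound 1 `COC(=O)/C=C/c1cccc(NC(=O)C2CCCCC2)c1`. In an assay on isolated protein with Bile acid receptor (Homo sapiens) as the target (a higher number here means that more compound is needed for the effect, a lower number that less compound is needed), compound 1 gives > 1000 nM, which is a limit of the assay and not a number. Compound 2 `COC(=O)/C=C/c1cccc(N(Cc2ccccc2)C(=O)C2CCCCC2)c1` carries a benzyl group in place of hydrogen on the amide-type nitrogen; in this assay compound 2 gives > 1000 nM, again only a limit. Compound 3 `COC(=O)/C=C/c1cccc(N(Cc2ccc(C(C)(C)C)cc2)C(=O)C2CCCCC2)c1` carries a tert-butyl group in place of hydrogen on an aromatic carbon of that benzyl; in this assay compound 3 gives > 1000 nM, once more a limit. Compound 3 thus stands at the limit, and the two other values shown sit there as well. The two measured steps, a step that the two limits leave unreadable from compound 1 to compound 2 and a step that the two limits leave unreadable from compound 2 to compound 3, cannot be sized, because the limit of > 1000 nM in this assay, at which 3 of the 3 values shown sit, holds every value in the set. Compound 4 `COC(=O)/C=C/c1cccc(N(Cc2cccc(OC)c2)C(=O)C2CCCCC2)c1` differs from compound 3 by 3-methoxyphenyl in place of 4-(tert-butyl)phenyl on a saturated chain carbon bound to an amide-type nitrogen. Neither measured step bears readably on this change, since both end at the limit, and no step beyond the scatter is visible anywhere in the series. The expected size of the step in this assay is a step that the limit leaves unreadable from compound 3 to compound 4, most probably ending at a limit again. Compound 4 is estimated in this assay at 3000 nM, with a range from 700 nM to 20000 nM.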

Compound 4, half-maximal effective concentration: > 1000 nM
Compound 4 gave a limit, no number; the forecaster's own chance of this, stated with the estimate: 75%; the middle value does not contradict the limit.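

In this assay compound 4 gives > 1000 nM, again a limit and not a number. The steps from compound 1, compound 2 and compound 3 to compound 4 therefore cannot be read, because all values rest on the same limit: the limit of > 1000 nM in this assay, at which 4 of the 4 values shown sit. The compounds shown leave open how far each lies beyond that limit, and whether the benzyl group or its substituents change the half-maximal effective concentration at all.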